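Diethylsulfamoyl series: piperidine amide substituent step

The compounds below may be only part of what the source reports. "The series", "measured", "known", "first", "only" and "open" are said of these compounds alone.

Measured so far in a functional assay on BXPC-3 cells (Homo sapiens) for inhibition, read by MTT assay, with a stated time of 7 days; on this read-out higher numbers stand for weaker inhibition and lower numbers for stronger inhibition:
compound 1 `CCN(CC)S(=O)(=O)c1ccc(S(=O)(=O)N2CCC[C@@H](C(=O)N3CCC(OC)CC3)C2)cc1`: 1420 nM
compound 2 `O=C([C@@H]1CCCN(S(=O)(=O)c2ccc(S(=O)(=O)C3CC3)cc2)C1)N1CCC(F)(F)CC1`: 129 nM
compound 3 `CN(C)S(=O)(=O)c1ccc(S(=O)(=O)N2CCC[C@@H](C(=O)N3CCC(F)(F)CC3)C2)cc1`: 560 nM

Compound 1 stands highest of the three numbers in this assay; compound 3 sits closer to it, and compound 2 sits furthest away. Among the compounds with values here, the only single-point step measured so far, a 4.3-fold higher number from compound 2 to compound 3 (0.64 log units; beyond the scatter), concerns the substituent on the aryl sulfonyl sulfur and not the amide portion. Compound 4 `CCN(CC)S(=O)(=O)c1ccc(S(=O)(=O)N2CCC[C@@H](C(=O)N3CCC(COC)CC3)C2)cc1` differs from compound 1 by methoxymethyl in place of methoxy on a saturated ring carbon. Within the data shown here, no measured step touches that part of the core, so the series gives no direction for this change, and the step of a 1.0-fold lower number from compound 1 to compound 4 (0.01 log units; within the scatter) is expected to stay within the scatter. Compound 4 is therefore estimated at 1400 nM, with a range from 500 nM to 4000 nM.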

Compound 4, half-maximal inhibitory concentration: 1360 nM
Compound 4: the middle estimate sits 1.0-fold (0.01 log units) above what was measured; measured number inside the range.
By their numbers in this assay, from the lowest: compound 2; then compound 3; then compounds 4 and 1 (each within the scatter of the next).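

In this assay, within the data shown here, a 1.0-fold lower number from compound 1 to compound 4 (0.02 log units; within the scatter) gives the first measured step in the amide portion of the series, and it shows that this ring carbon accepts methoxymethyl in place of methoxy with no readable change. The hydrogen-bond acceptor and donor counts stay the same across this step, so the result speaks only to the larger chain, not to a new functional group. No supporting evidence bears on why the number holds.

On these data alone, whether an amine, a carboxylic acid or a longer ether chain at this ring carbon would shift the number remains open. Also open, as far as these compounds go, is whether the same change stays silent with the sulfonyl substituents of compound 2 or compound 3.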